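Swapping a Ring Amine for a Thioether on the Core

The compounds below may be only part of what the source reports. "The series", "measured", "known", "first", "only" and "open" are said of these compounds alone.

Among the compounds with values here, compound 2 `CC(C(=O)NCc1ccc(C(F)(F)Cl)nc1N1CCCCCC1)c1ccc(NS(C)(=O)=O)c(F)c1` gives 0.5 nM in an assay on CHO cells for antagonist activity at transient receptor potential cation channel subfamily V member 1 (Homo sapiens), read by FLIPR (a higher number here means a weaker inhibitor, a lower number a stronger inhibitor), the lowest of the two numbers measured so far; compound 1 `CC1CCN(c2nc(-c3ccc(F)cc3)ccc2CNC(=O)C(C)c2ccc(NS(C)(=O)=O)c(F)c2)CC1` gives 59 nM in this assay, a gap far beyond the usual scatter. Compound 3 `CC(C(=O)NCc1ccc(C(F)(F)Cl)nc1SC1CCCCC1)c1ccc(NS(C)(=O)=O)c(F)c1` has not yet been measured; it differs from compound 2 by cyclohexylsulfanyl in place of azepan-1-yl on an aromatic carbon. Within the data shown here, no measured pair shows this exact change, so the step can only be guessed: the estimated step of a 6.0-fold higher number from compound 2 to compound 3 (0.78 log units; beyond the scatter) is a modest loss, somewhat beyond the scatter. In this assay compound 3 is expected to give 3 nM, within a range from 0.5 nM to 20 nM.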

Compound 3, inhibition constant: 3 nM
For compound 3 middle estimate and measured number coincide at the digits printed; the range from low to high includes it.
By their numbers in this assay, from the lowest: compound 2; then compound 3; then compound 1.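

Compounds 1 and 2 differ in more than one place, whereas compounds 2 and 3 differ only in the group next to the ring nitrogen, so this change can be read alone. In this assay, cyclohexylsulfanyl in place of azepan-1-yl gives a 6.0-fold higher number from compound 2 to compound 3 (0.78 log units; beyond the scatter), a modest loss, which shows that a ring nitrogen attached to the core is not essential for low-nanomolar activity. Nothing measured here explains the loss.

The swap changes the linking atom and the ring together, and the compounds shown cannot separate the two. From the compounds shown here alone, how a cyclohexyloxy or piperidin-1-yl group would behave at this position remains open.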